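This account rests on a few compounds, and the source may have more. Where it says the series, first, only, none or still open, it means among the compounds named here.

Compound 1 `Cc1cccc2cc3c(nc12)-c1nc2ccccc2n1C3`: 23800 nM
Compound 2 `Cc1ccc2nc3c(cc2c1)Cn1c-3nc2ccccc21`: 62500 nM
Compound 3 `COc1cccc2cc3c(nc12)-c1nc2ccccc2n1C3`: 20000 nM

In a functional assay on LNCaP cells (Homo sapiens) for cytotoxicity, read by MTT assay, with a stated time of 72 h (a lower number here means a stronger inhibitor, a higher number a weaker inhibitor), compound 1 gives 23800 nM and compound 3 gives 20000 nM. The two share a core and differ by methoxy in place of methyl on an aromatic carbon, and that change brought a 1.2-fold lower number from compound 1 to compound 3 (0.08 log units; within the scatter). Compound 2 has the same atoms as compound 1 joined differently; the difference between the two cores is not broken down here. In this assay compound 2 gives 62500 nM, the highest of the three numbers, beyond the scatter from both compound 1 and compound 3.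

Compound 4 `COc1ccc2nc3c(cc2c1)Cn1c-3nc2ccccc21` has not yet been measured in this assay. It differs from compound 2 by methoxy in place of methyl on an aromatic carbon. This is the same kind of change as that from compound 1 to compound 3, though not the same: there the place was ortho to a fused ring and meta to a fused ring, here it is meta to a fused ring and para to a fused ring. Because a 1.2-fold lower number from compound 1 to compound 3 (0.08 log units; within the scatter) lay within the scatter, the step from compound 2 to compound 4 is expected to be small as well, about a 1.1-fold lower number from compound 2 to compound 4 (0.06 log units; within the scatter). Compound 4 is therefore estimated at 55000 nM, with a likely range from 25000 nM to 120000 nM, resting on compound 2 at 62500 nM.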

Compound 4, half-maximal inhibitory concentration: 24700 nM
Compound 4: middle estimate off by 2.2-fold (0.35 log units), on the high side; the whole stated range lies above it.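

In this assay, methoxy in place of methyl on an aromatic carbon brought a 2.5-fold lower number from compound 2 to compound 4 (0.40 log units; beyond the scatter). Set beside the same change on the core of compound 1, this step does not differ from the earlier one by more than two such steps would scatter: the same change on two cores in this assay, a 1.2-fold lower number (0.08 log units; within the scatter) from compound 1 to compound 3 and a 2.5-fold lower number (0.40 log units; beyond the scatter) from compound 2 to compound 4, 2.1-fold (0.33 log units) apart, within the scatter of two such steps. The two pairs are therefore compatible with one shared effect of the change on both cores, but they do not show that the effect is the same, nor that the core or the place of the group has no bearing on it, and two pairs say nothing about a further core.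

The compounds shown carry only methyl or methoxy at these places, so the series offers no view of any other group there. From the compounds shown here alone, it remains open how an amine, a carboxylic acid, a chlorine atom or a longer chain such as ethoxy would fare at these places on either core.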